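Cyclopentyl in place of isopropyl: compound 3 expected near compound 2

The source may report more compounds than this note shows. Statements on the series, on what has been measured and on what is new or still open speak of the compounds shown alone.

Among the compounds with values here, the series so far holds two measured compounds. Compound 1 `Cc1c(C(C)C)c(=O)on1C(=O)N1CCC(Cc2ccccc2)CC1` gives 102 nM in an assay (strain Wistar) for inhibition of Hormone-sensitive lipase (Rattus norvegicus), read by spectrophotometry; a higher number here means a weaker inhibitor, a lower number a stronger inhibitor. Compound 2 `Cc1c(C(C)C)c(=O)on1C(=O)N1CCC(c2ccccc2)CC1` gives 12 nM in this assay. Within the data shown here, the one measured step, an 8.5-fold lower number from compound 1 to compound 2 (0.93 log units; beyond the scatter), concerns the group on the saturated ring and not the group on the aromatic ring. Among the measured compounds shown here, compound 2 thus holds the lower of the two numbers, with compound 1 as its only neighbour.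

Compound 3 `Cc1c(C2CCCC2)c(=O)on1C(=O)N1CCC(c2ccccc2)CC1` differs from compound 2 at one place: cyclopentyl in place of isopropyl on an aromatic carbon. For the measured compounds named here, no measured step touches this position; the step from compound 1 to compound 2 changes a different part of the molecule and gives no guide to the size or direction of an isopropyl-to-cyclopentyl exchange. With nothing in the data bearing on this change, the expectation is no step beyond the scatter, with the range widened to allow for either direction. For compound 3 the estimate in this assay is therefore 12 nM, between 4 nM and 40 nM. The expected step is no change at the digits printed from compound 2 to compound 3 (within the scatter), a placeholder until the measurement is in hand.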

Compound 3, half-maximal inhibitory concentration: 24 nM
The estimate for compound 3 lay 2.0-fold (0.30 log units) below the measured number; measured number inside the range.
By their numbers in this assay, from the lowest: compounds 2 and 3 (each within the scatter of the next); then compound 1.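

Within the data shown here, the aromatic carbon two ring bonds from the ring nitrogen now has its first reading: in this assay, cyclopentyl in place of isopropyl gives a 2.0-fold higher number from compound 2 to compound 3 (0.30 log units; within the scatter), the only step so far at this position. Isopropyl, with 3 heavy atoms and no ring, and cyclopentyl, with 5 heavy atoms and one five-membered non-aromatic ring of carbon only, therefore cannot be told apart in this assay, and neither compound 2 nor compound 3 can be ranked above the other. Nothing in hand bears on the reason this exchange leaves the number within the scatter.

Open, as far as these compounds go, is whether the position holds a number in the same range with a larger or different group, such as cyclohexyl or phenyl, or with a smaller one, such as methyl or hydrogen, and whether a chain carrying an amine or a carboxylic acid would do the same. Also open, from the compounds shown here alone, is whether the same exchange would read alike with benzyl in place of phenyl on the saturated ring, as in compound 1.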